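The source may hold more compounds than are shown below. What is called first, only, known or untested is meant among the compounds shown, and "the series" means these compounds.

In an ADME assay on HeLa cells (Homo sapiens) for cytotoxicity, read by ATP content, with a stated time of 3 days (on this read-out higher numbers stand for lower toxicity in this test and lower numbers for higher toxicity in this test), compound 1, with the structure `O=c1n(Cc2cc3cc(Cl)ccc3n2CCCCF)c2cnccc2n1C1CC1`, gives > 50000 nM, which is a limit of the assay rather than a number. Compound 2, with the structure `O=c1n(Cc2cc3ccncc3n2CCCCO)c2cnccc2n1C1CC1`, likewise gives in this assay only the assay limit > 100000 nM. The two values sit at limits, one at the limit of > 50000 nM in this assay, at which 1 of the 2 values shown sits, and one at the limit of > 100000 nM in this assay, at which 1 of the 2 values shown sits. Compound 3, with the structure `CC(C)(O)CCCn1c(Cn2c(=O)n(C3CC3)c3ccncc32)cc2cc(Cl)ccc21`, differs from compound 1 by 1-hydroxy-1-methylethyl in place of fluoromethyl on a saturated chain carbon, three bonds along the chain from an aromatic nitrogen. No measured step sizes this change, so the expected shift a step that the limit leaves unreadable from compound 1 to compound 3 is none beyond the scatter. Compound 3 is estimated at 80000 nM, between 30000 nM and 200000 nM, most likely again only a limit.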

Compound 3, half-maximal cytotoxic concentration: > 50000 nM
Compound 3: no number, only a limit; the forecaster's own chance of this, stated with the estimate: 80%; the middle value does not contradict the limit.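

No step can be read from compound 1 to compound 3, since both values are limits: the limit of > 50000 nM in this assay, at which 2 of the 3 values shown sit.

The compounds shown leave open whether 1-hydroxy-1-methylethyl in place of fluoromethyl changes the read-out in this assay at all.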